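The source may report more compounds than this note shows. Statements on the series, on what has been measured and on what is new or still open speak of the compounds shown alone.

Compound 1 `CC(=O)Oc1ccccc1C(=O)Oc1ccccc1/C=C/C=O` gives 20300 nM in a functional assay on HCT-8 cells (Homo sapiens) for antiproliferative activity, read by MTT assay, with a stated time of 72 h; a lower number here means a stronger inhibitor, a higher number a weaker inhibitor.
Compound 2 `COc1ccc(OC(=O)c2ccccc2OC(C)=O)c(/C=C/C=O)c1` gives 9300 nM in this assay.
Compound 3 `CC(=O)Oc1ccccc1C(=O)Oc1ccc(Cl)cc1/C=C/C=O` gives 4300 nM in this assay.

Among these three numbers compound 1 stands highest. Compound 2 lies nearest to it, with a 2.2-fold lower number from compound 1 to compound 2 (0.34 log units; beyond the scatter), and compound 3 furthest, with a 4.7-fold lower number from compound 1 to compound 3 (0.67 log units; beyond the scatter). Compound 4 `CC(=O)Oc1ccccc1C(=O)Oc1ccc(Br)cc1/C=C/C=O` differs from compound 1 in one place: bromo in place of hydrogen on an aromatic carbon.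

The step that bears most directly on this change is the one in which chloro in place of hydrogen on an aromatic carbon gave a 4.7-fold lower number from compound 1 to compound 3 (0.67 log units; beyond the scatter), a modest but real gain beyond the scatter. The comparison of compound 2 with compound 3, a 2.2-fold lower number from compound 2 to compound 3 (0.34 log units; beyond the scatter), shows that a halogen at that carbon outdid methoxy as well. A bromo entering where chloro entered is therefore expected to move this assay downward by a modest step of roughly the same size, not beyond what chloro achieved by more than the scatter.

Compound 4 is thus estimated to give 4000 nM, expected to fall between 1800 nM and 9000 nM, which means an expected step of a 5.1-fold lower number from compound 1 to compound 4 (0.71 log units; beyond the scatter).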

Compound 4, half-maximal inhibitory concentration: 5600 nM
Compound 4: middle estimate off by 1.4-fold (0.15 log units), on the low side; the range from low to high includes it.
By their numbers in this assay, from the lowest: compounds 3, 4 and 2 (each within the scatter of the next, the first and the last beyond it); then compound 1.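

At the carbon para to a large group, bromo, like chloro, gives a real gain over hydrogen in this assay with a 3.6-fold lower number from compound 1 to compound 4 (0.56 log units; beyond the scatter) and so the gain at this position is not confined to a single halogen. The two halogens cannot be told apart here, with a 1.3-fold higher number from compound 3 to compound 4 (0.11 log units; within the scatter) as the step between them. The edge over methoxy seen for chloro is not repeated by bromo, with a 1.7-fold lower number from compound 2 to compound 4 (0.22 log units; within the scatter) as the step, so compound 4 goes against any claim that both halogens outdo methoxy at this carbon.

No measurement in hand explains any of these steps. As far as these compounds go, it remains open how a fluoro group, an amine or a carboxylic acid at this carbon would behave, and whether bromo would give a similar step elsewhere on this ring.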